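The source may hold more compounds than are shown below. What is called first, only, known or untested is meant among the compounds shown, and "the series" means these compounds.

The set comprises three measured compounds and one awaiting measurement, all examined in a functional assay on MCF7 cells (Homo sapiens) for antiproliferative activity, read by sulforhodamine B assay, with a stated time of 72 h; a lower number here means a stronger inhibitor, a higher number a weaker inhibitor. Compound 1 `C=C1CCC[C@H]2[C@](C)(CC3=C(O)C(=O)C=C(OC)C3=O)[C@@H](C)CC[C@@]12C` returns no number but a limit of the assay, > 10000 nM. Compound 2 `C=C1CCC[C@H]2[C@](C)(CC3=C(O)C(=O)C(CCCCC(C)=O)=C(OC)C3=O)[C@@H](C)CC[C@]12C` likewise gives only a limit, > 10000 nM. Compound 3 `C=C1CCC[C@H]2[C@](C)(CC3=C(O)C(=O)C=C(NCC(C)C)C3=O)[C@@H](C)CC[C@]12C` too reaches only a limit in this assay, > 10000 nM. Among the compounds with values here, compound 3 therefore stands exactly where the other two measured compounds stand: at the limit of > 10000 nM in this assay, at which 3 of the 3 values shown sit, so that no one of the three can be called weaker or stronger than another, and no step between measured compounds can be drawn.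

Compound 4 `C=C1CCC[C@H]2[C@](C)(CC3=C(O)C(=O)C=C(OC)C3=O)[C@@H](C)CC[C@]12C` is the compound not yet measured. It differs from compound 3 in one place: methoxy in place of isobutylamino on a double-bonded ring carbon. Within the data shown here, nothing among the measured compounds shows what this exchange does in this assay. Because the limit of > 10000 nM in this assay, at which 3 of the 3 values shown sit, describes every measured compound, the step from compound 3 to compound 4 is expected to bring no change beyond the scatter, and the expected step in this assay is a step that the limit leaves unreadable from compound 3 to compound 4. Compound 4 is accordingly estimated at 15000 nM in this assay, with a range from 5000 nM to 50000 nM, and most probably the assay will again report only a limit for compound 4.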

Compound 4, half-maximal inhibitory concentration: > 10000 nM
Compound 4 gave a limit, no number; the forecaster's own chance of this, stated with the estimate: 80%; the middle value does not contradict the limit.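

Within the data shown here, compound 4, like compounds 1, 2 and 3, gives only a limit, so no step from any of them to compound 4 can be read: the limit of > 10000 nM in this assay, at which 4 of the 4 values shown sit. The compounds shown leave open whether methoxy, isobutylamino, 4-acetylbutyl or the configuration as drawn alters antiproliferative activity on the shared core at all.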